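The compounds below may be only part of what the source reports. "The series", "measured", "known", "first", "only" and "open" are said of these compounds alone.

Measured so far:
Compound 1 `O=C(O)c1cc2cc(-c3cc(OC(F)(F)F)ccc3F)ccc2o1` — in a functional assay on isolated protein for agonist activity at Free fatty acid receptor 1 (Homo sapiens), read by HTRF and inositol phosphate accumulation, with a stated time of 60 min (a lower number here means that less compound is needed, a higher number that more compound is needed for the effect), compound 1 gives > 9950 nM, which is a limit of the assay.
Compound 2 `Fc1ccc(OC(F)(F)F)cc1-c1ccc2oc(CCc3nn[nH]n3)cc2c1` — in this assay compound 2 gives > 9950 nM, again a limit.
Compound 3 `CC(Cc1cc2cc(-c3cc(OC(F)(F)F)ccc3F)ccc2o1)C(=O)O` — in this assay compound 3 gives > 9950 nM, also a limit.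

Compound 3 therefore stands at the limit of > 9950 nM in this assay, at which 3 of the 3 values shown sit, together with the other two, with no number to place it. The steps a step that the two limits leave unreadable from compound 1 to compound 3 and a step that the two limits leave unreadable from compound 2 to compound 3 cannot be read, nor can a step that the two limits leave unreadable from compound 1 to compound 2.

Compound 4 `CC(CC(=O)O)c1cc2cc(-c3cc(OC(F)(F)F)ccc3F)ccc2o1` differs from compound 3 by 1-(carboxymethyl)ethyl in place of 2-carboxypropyl on an aromatic carbon. Among the compounds with values here, no measured step bears on this rearrangement, since every step among compound 1, compound 2 and compound 3 ends at the limit. The expected step is an at least 1.2-fold lower number from compound 3 to compound 4 (0.09 log units; that floor lies within the scatter), with a limit again the likelier outcome. Compound 4 is estimated at 8000 nM, between 2000 nM and 30000 nM.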

Compound 4, half-maximal effective concentration: > 9950 nM
Compound 4 was reported as a limit; the forecaster's own chance of this, stated with the estimate: 65%; middle value at least 1.2-fold (0.09 log units) from the limit.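

In this assay compound 4 gives > 9950 nM, a limit. No step among compound 1, compound 2, compound 3 and compound 4 can be read: the limit of > 9950 nM in this assay, at which 4 of the 4 values shown sit.

The compounds shown leave open how these four rank, and whether any other group in this place on the shared core gives a measurable value in this assay.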